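Replacing trifluoromethyl with hydroxy on the aniline ring

The source may report more compounds than this note shows. Statements on the series, on what has been measured and on what is new or still open speak of the compounds shown alone.

Measured compounds:
compound 1 `COc1cc(-c2nn(-c3ccccc3)cc2C(=O)/C=C\Nc2ccc(F)cc2)cc(OC)c1OC` 4780 nM
compound 2 `COc1cc(-c2nn(-c3ccccc3)cc2C(=O)/C=C\Nc2ccc(Cl)cc2)cc(OC)c1OC` 3210 nM
compound 3 `COc1cc(-c2nn(-c3ccccc3)cc2C(=O)/C=C\Nc2ccc(C(F)(F)F)cc2)cc(OC)c1OC` > 50000 nM

Three compounds share one core and differ only in the group on the aniline ring. In a functional assay on U-87MG ATCC cells (Homo sapiens) for antiproliferative activity, read by MTT assay, with a stated time of 48 h (on this read-out higher numbers stand for weaker inhibition and lower numbers for stronger inhibition), compound 1 gives 4780 nM and compound 2 gives 3210 nM. For compound 3 the assay reports only a limit, > 50000 nM, and not a number, so compound 3 stands at the weak end of the measured range (the limit of > 50000 nM in this assay, at which 1 of the 3 values shown sits).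

Compound 4 `COc1cc(-c2nn(-c3ccccc3)cc2C(=O)/C=C\Nc2ccc(O)cc2)cc(OC)c1OC` is not yet measured. It differs from compound 3 by hydroxy in place of trifluoromethyl on an aromatic carbon.

For the measured compounds named here, two measured steps bear on this change, both leading into the trifluoromethyl compound: an at least 10-fold higher number from compound 1 to compound 3 (1.01 log units; beyond the scatter) and an at least 15-fold higher number from compound 2 to compound 3 (1.19 log units; beyond the scatter). The step of a 1.5-fold lower number from compound 1 to compound 2 (0.17 log units; within the scatter) shows that exchanging one small group for another at this position makes little difference. Going from trifluoromethyl back to a single-atom group is expected to reverse the large loss, giving a large step toward lower numbers in this assay, an at least 8.3-fold lower number from compound 3 to compound 4 (0.92 log units; beyond the scatter).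

Compound 4 is therefore expected to give about 6000 nM in this assay, estimated between 1500 nM and 30000 nM.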

Compound 4, half-maximal inhibitory concentration: 1800 nM
Estimate against measurement, compound 4: 3.3-fold (0.52 log units) above, and the stated range covers the measured number.
By their numbers in this assay, from the lowest: compounds 4, 2 and 1 (each within the scatter of the next, the first and the last beyond it). At a limit, above all of these: compound 3.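

In this assay, the position on the aniline ring accepts more than the two halogens: hydroxy, which carries a hydrogen-bond donor and acceptor where trifluoromethyl carries neither, brings back activity in the change that gives an at least 27-fold lower number from compound 3 to compound 4 (1.44 log units; beyond the scatter), and this step has no upper end. It can be stated only as a minimum, since compound 3 stands at a limit and not at a number: the limit of > 50000 nM in this assay, at which 1 of the 4 values shown sits. Set against the halogens, the readings of a 1.8-fold lower number from compound 2 to compound 4 (0.25 log units; within the scatter) and a 2.7-fold lower number from compound 1 to compound 4 (0.42 log units; beyond the scatter) place hydroxy level with chloro within the scatter and modestly ahead of fluoro, so among these four groups the large loss belongs to trifluoromethyl alone and does not come from leaving the halogens.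

Going by these compounds, whether a methoxy group, an amine or a carboxylic acid on the same carbon would behave like hydroxy or like trifluoromethyl stays open. The compounds shown also give no measured property of these groups, so they cannot say why trifluoromethyl stands apart from the other three.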